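The source may report more compounds than this note shows. Statements on the series, on what has been measured and on what is new or still open speak of the compounds shown alone.

Of the compounds shown here, three that share one core have been tested in a functional assay for inhibition of sodium/hydrogen exchanger (Oryctolagus cuniculus); a lower number here means a stronger inhibitor, a higher number a weaker inhibitor. Compound 1 `CS(=O)(=O)c1cc(C(=O)N=C(N)N)c(Cl)cc1Cl` gives 140 nM in this assay. Compound 2 `Cc1c(C(=O)N=C(N)N)cc(S(C)(=O)=O)c(Cl)c1Cl` gives 29 nM in this assay. Compound 3 `Cc1cc(C2CCCCC2)c(S(C)(=O)=O)cc1C(=O)N=C(N)N` gives 22 nM in this assay, a number close to that of compound 2 and clearly apart from that of compound 1. A fourth compound, compound 4 `Cc1cc(O)c(S(C)(=O)=O)cc1C(=O)N=C(N)N`, awaits measurement. It differs from compound 3 in one place: hydroxy in place of cyclohexyl on an aromatic carbon. Within the data shown here, no measured pair shows this exact change, so its size is uncertain; a step toward a higher number in this assay, beyond the usual scatter, is nevertheless expected. Compound 4 is therefore estimated at 150 nM, within a range from 40 nM to 600 nM. That expectation corresponds to a step of a 6.8-fold higher number from compound 3 to compound 4 (0.83 log units; beyond the scatter).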

Compound 4, half-maximal inhibitory concentration: 220 nM
For compound 4 the middle estimate is 1.5-fold (0.17 log units) below the measured one; the measured number falls inside the stated range.
By their numbers in this assay, from the lowest: compounds 3 and 2 (each within the scatter of the next); then compounds 1 and 4 (each within the scatter of the next).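

Placing hydroxy instead of cyclohexyl on the aromatic carbon ortho to the methylsulfonyl group gives a 10-fold higher number from compound 3 to compound 4 (1.00 log units; beyond the scatter) in this assay. Among these compounds, this is the first direct comparison of two compounds that differ in one place, and it shows that the group on this carbon can clearly change the number. Nothing measured here explains the size of this step. As far as these compounds go, it remains open whether the step comes from losing cyclohexyl or from gaining hydroxy. From the compounds shown here alone, how methoxy or an amine on this carbon would compare with these two groups also remains open.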